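The compounds below may be only part of what the source reports. "The series", "measured", "known", "first", "only" and "open" are said of these compounds alone.

Compound 1 `COc1cc2ncnc(Nc3ccc(F)c(Cl)c3)c2cc1OCCCCC(=O)Nc1ccc(S(N)(=O)=O)cc1` gives 5020 nM. Compound 2 `COc1cc2ncnc(Nc3ccc(Cl)c(C(F)(F)F)c3)c2cc1OCCCCC(=O)Nc1ccc(S(N)(=O)=O)cc1` gives 3910 nM.

In a functional assay on A-431 cells (Homo sapiens) for antiproliferative activity, read by MTT assay, with a stated time of 72 h (a lower number here means a stronger inhibitor, a higher number a weaker inhibitor), compound 2 has the lowest of the two numbers, and compound 1 lies within the scatter of it. Compound 3 is `COc1cc2ncnc(Nc3ccc(Cl)cc3)c2cc1OCCCCC(=O)Nc1ccc(S(N)(=O)=O)cc1`; it differs from compound 2 by hydrogen in place of trifluoromethyl on an aromatic carbon. Among the compounds with values here, the only measured step, a 1.3-fold lower number from compound 1 to compound 2 (0.11 log units; within the scatter), also alters the same aryl group and stayed within the scatter, so it offers weak guidance here. The number for compound 3 is therefore expected to change little, a 1.2-fold higher number from compound 2 to compound 3 (0.06 log units; within the scatter). Compound 3 is estimated to give 4500 nM, within a range from 2000 nM to 10000 nM.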

Compound 3, half-maximal inhibitory concentration: 7120 nM
Compound 3: the middle estimate sits 1.6-fold (0.20 log units) below what was measured; the measured number falls inside the stated range.
By their numbers in this assay, from the lowest: compounds 2, 1 and 3 (each within the scatter of the next).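

In this assay, hydrogen in place of trifluoromethyl on this aromatic carbon gives a step still within the scatter (a 1.8-fold higher number from compound 2 to compound 3 (0.26 log units; within the scatter)), so even losing this whole group does not separate the two compounds. The step to the 4-chlorophenyl group from the 3-chloro-4-fluorophenyl group is also within the scatter (a 1.4-fold higher number from compound 1 to compound 3 (0.15 log units; within the scatter)), so no aryl change among these three compounds stands out. No measurement shown offers an explanation for these numbers. From the compounds shown here alone, whether an amine or a nitrile on this aromatic carbon, ortho to the chloro group, would move the number beyond the scatter remains open. So does the effect of a longer chain.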